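A few compounds are considered here, and "the series" means these few. Any claim that something is new, unique, unknown or untested is made for them only; others in the source may bear on it.

Three compounds have been measured in a functional assay on MV4-11 cells (Homo sapiens) for cytotoxicity, read by colorimetric assay and MTT assay, with a stated time of 3 days, tested at 1 uM; on this read-out higher numbers stand for a weaker effect at the one concentration tested and lower numbers for a stronger effect:

compound 1 `COc1ccc(-c2nc(-c3ccccc3)c(-c3ccc4c(c3)NC(=O)CO4)[nH]2)cc1` gives 108%
compound 2 `Cc1ccccc1-n1cc(-c2ccccc2)c(-c2ccc3c(c2)NC(=O)CO3)n1` gives 99.4%
compound 3 `O=C1COc2ccc(-c3[nH]c(-c4c[nH]c5ncccc45)nc3-c3ccccc3)cc2N1` gives 111%

Compound 2 holds the lowest of the three numbers, but its distance to compound 1 lies within the scatter, so the two cannot be told apart; only compound 3 stands clearly apart from compound 2, beyond the scatter. Among the compounds with values here, the one step that joins two measured compounds in one place is a number 3 percentage points higher from compound 1 to compound 3 (within the scatter), a change on an aromatic carbon of the shared core.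

Compound 4 `O=C1COc2ccc(-c3nn(-c4ccc(F)cc4)cc3-c3ccccc3)cc2N1` is not yet measured. It differs from compound 2 in this way: 4-fluorophenyl in place of 2-methylphenyl on an aromatic nitrogen. Within the data shown here, this exchange sits on an aromatic nitrogen of the five-membered aromatic ring, a place that none of the measured steps touches; the step from compound 1 to compound 3 concerns a different position and a different kind of group, and there is no measured pair that swaps one six-membered aromatic ring of carbon only for another at this nitrogen. Among the measured compounds shown here, nothing among the measured compounds therefore supports a shift beyond the scatter in this assay. For compound 4 the step of a number 0.6 percentage points higher from compound 2 to compound 4 (within the scatter) is expected to stay within the scatter. Compound 4 is estimated at 100%, in a range from 88% to 112%.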

Compound 4, a percentage reported as activity, at one concentration (the size of the read-out at that concentration, not a potency): 107%
Beside the measured number, compound 4's estimate is 7 percentage points below it, and the stated range covers the measured number.
By their numbers in this assay, from the lowest: compounds 2, 4, 1 and 3 (each within the scatter of the next, the first and the last beyond it).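

In this assay, within the data shown here, the exchange of 2-methylphenyl for 4-fluorophenyl on the aromatic nitrogen of the five-membered ring, the only measured change at this position, appears as a number 7.6 percentage points higher from compound 2 to compound 4 (within the scatter) and so gives no distinction between the two compounds. This shows that, for these two groups, each a six-membered aromatic ring of carbon only, moving from a methyl-bearing ring to a fluorine-bearing one at this nitrogen does not separate the read-out from the scatter, which the earlier step on an aromatic carbon could not show for this place. Nothing available explains the size of this step or links it to a property of either group.

The compounds shown leave open whether anything other than a substituted phenyl ring at this nitrogen, such as a piperidine, a longer alkyl chain ending in an amine, or a chain carrying a carboxylic acid, would move the number beyond the scatter. They also leave open how these compounds compare at other concentrations, since a read-out at one concentration gives no potency.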